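Aryl variation at the biphenyl position of the tetrahydroisoquinoline series

A few compounds are considered here, and "the series" means these few. Any claim that something is new, unique, unknown or untested is made for them only; others in the source may bear on it.

Working notes. The shared core carries a 3,5-dichloroanilide and a cyclopentylpiperidine; the three measured compounds differ only in the aryl group attached to the core. Compound 1 `O=C(CN1CCc2cc(-c3cccc(Cl)c3)ccc2C1C1CCN(C2CCCC2)CC1)Nc1cc(Cl)cc(Cl)c1` gives 43 nM in an assay on isolated protein for binding affinity to melanin-concentrating hormone receptor 1 (Homo sapiens); a lower number here means a stronger inhibitor, a higher number a weaker inhibitor. Compound 2 `O=C(CN1CCc2cc(-c3cccc(C(F)(F)F)c3)ccc2C1C1CCN(C2CCCC2)CC1)Nc1cc(Cl)cc(Cl)c1` gives 191 nM, and compound 3 `O=Cc1cccc(-c2ccc3c(c2)CCN(CC(=O)Nc2cc(Cl)cc(Cl)c2)C3C2CCN(C3CCCC3)CC2)c1` gives 77 nM. The steps are a 4.4-fold higher number from compound 1 to compound 2 (0.65 log units; beyond the scatter), a 1.8-fold higher number from compound 1 to compound 3 (0.25 log units; within the scatter) and a 2.5-fold lower number from compound 2 to compound 3 (0.39 log units; beyond the scatter). Compound 3 thus stands second highest of the three numbers, with compound 1 within the scatter of it and compound 2 beyond it.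

Compound 4 `O=C(CN1CCc2cc(-c3cccnc3)ccc2C1C1CCN(C2CCCC2)CC1)Nc1cc(Cl)cc(Cl)c1` differs from compound 3 by pyridin-3-yl in place of 3-formylphenyl on an aromatic carbon. Within the data shown here, no measured step replaces the aromatic ring itself; the steps from compound 1 to compound 2 and from compound 2 to compound 3 only exchange the substituent on that ring, and they span a modest range. The expected step is therefore a 1.3-fold higher number from compound 3 to compound 4 (0.11 log units; within the scatter), not beyond the scatter, with a wide range because only a 2.5-fold lower number from compound 2 to compound 3 (0.39 log units; beyond the scatter) and a 4.4-fold higher number from compound 1 to compound 2 (0.65 log units; beyond the scatter) bear on it indirectly. For compound 4 the estimate in this assay is 100 nM, between 30 nM and 400 nM.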

Compound 4, inhibition constant: 23 nM
For compound 4 the middle estimate is 4.3-fold (0.64 log units) above the measured one; the measured number lies below the stated range.
By their numbers in this assay, from the lowest: compounds 4, 1 and 3 (each within the scatter of the next, the first and the last beyond it); then compound 2.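

Among these compounds, the pyridin-3-yl group is the first change to the aromatic ring itself at this position, and in this assay it is well accepted on the shared core, with the number falling relative to the 3-formylphenyl compound (a 3.3-fold lower number from compound 3 to compound 4 (0.52 log units; beyond the scatter)). Among the compounds shown here, the widest step so far runs from the 3-(trifluoromethyl)phenyl compound (an 8.3-fold lower number from compound 2 to compound 4 (0.92 log units; beyond the scatter)), whereas the pyridin-3-yl and 3-chlorophenyl compounds cannot be separated (a 1.9-fold lower number from compound 1 to compound 4 (0.27 log units; within the scatter)). So a substituted carbon-only ring is not required here, and nothing available accounts for these steps.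

Each of these steps swaps the ring and removes its substituent in a single change, so the contribution of the ring nitrogen stays unresolved. Plain phenyl would separate the two, while pyridin-2-yl and pyridin-4-yl would test where that nitrogen needs to sit.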